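Compound 4 against the assay limit

This account rests on a few compounds, and the source may have more. Where it says the series, first, only, none or still open, it means among the compounds named here.

Values in a functional assay on L1210 cells (Mus musculus); on this read-out higher numbers stand for weaker inhibition and lower numbers for stronger inhibition:
- compound 1 `CCOC[C@H]1OC(n2c(Cl)nc3cc(Cl)c(Cl)cc32)[C@H](O)[C@@H]1O`: 59000 nM
- compound 2 `CCCCOC[C@H]1OC(n2c(Cl)nc3cc(Cl)c(Cl)cc32)[C@H](O)[C@@H]1O`: > 100000 nM
- compound 3 `O[C@@H]1[C@@H](CF)OC(n2c(Cl)nc3cc(Cl)c(Cl)cc32)[C@@H]1O`: > 100000 nM

Compound 2 reads > 100000 nM, which is a limit and not a number. Compound 3 reads > 100000 nM, also a limit. Compound 4 `[N-]=[N+]=NC[C@H]1OC(n2c(Cl)nc3cc(Cl)c(Cl)cc32)[C@H](O)[C@@H]1O` differs from compound 2 by azido in place of butoxy on a saturated chain carbon bound to a saturated ring carbon. The nearest measured steps are an at least 1.6-fold higher number from compound 1 to compound 2 (0.22 log units; that floor lies within the scatter) and an at least 1.6-fold higher number from compound 1 to compound 3 (0.22 log units; that floor lies within the scatter), while a step that the two limits leave unreadable from compound 2 to compound 3 gives no size. No step beyond the scatter is therefore expected in this assay. The expected change is an at least 1.2-fold lower number from compound 2 to compound 4 (0.09 log units; that floor lies within the scatter). For compound 4 the estimated value is 80000 nM, with an expected range of 30000 nM to 150000 nM.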

Compound 4, half-maximal inhibitory concentration: 80000 nM
For compound 4 middle estimate and measured number coincide at the digits printed; low and high end bracket the measured number.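

In this assay compound 4 gives a measured number with azido on a saturated chain carbon bound to a saturated ring carbon, so this position tolerates a group other than ethoxy without reaching the limit. The step of a 1.4-fold higher number from compound 1 to compound 4 (0.13 log units; within the scatter) leaves azido and ethoxy unseparated here. The steps of an at least 1.2-fold lower number from compound 2 to compound 4 (0.09 log units; that floor lies within the scatter) and an at least 1.2-fold lower number from compound 3 to compound 4 (0.09 log units; that floor lies within the scatter) are floors only, and both stay within the scatter; they rest on a limit: the limit of > 100000 nM in this assay, at which 2 of the 4 values shown sit.

No change at this position yet gives a step beyond the scatter. On these data alone, whether an amine or a carboxylic acid on this chain carbon would do so stays open.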